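Swapping a Bromophenyl for a Methylphenyl on the Core

The source may hold more compounds than are shown below. What is called first, only, known or untested is meant among the compounds shown, and "the series" means these compounds.

Compound 1 `O=C(NO)c1ccc(NCc2nc(-c3ccc(Br)cc3)nn2-c2ccccc2)cc1` was tested in an assay on Sf9 cells for inhibition of protein deacetylase HDAC6 (Homo sapiens), read by fluorescence, with a stated time of 40 min, tested at 100 nM (a lower number here means less inhibition, a higher number more inhibition at the concentration tested (going by the name of the read-out)), where compound 1 gives 54.7%. A second compound, compound 2 `Cc1ccc(-n2nc(-c3ccccc3)nc2CNc2ccc(C(=O)NO)cc2)cc1`, gives 60.7% in this assay, a number only a few points higher, so the two results sit within the usual scatter of each other, and compound 1 simply holds the lower of the two numbers shown. Among the measured compounds shown here, no pair of measured compounds differing in a single place is available, so the size of any one change cannot be read from these data.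

Compound 3 `Cc1ccccc1-c1nc(CNc2ccc(C(=O)NO)cc2)n(-c2ccccc2)n1` has not yet been measured. Compared with compound 1 it differs in one place: 2-methylphenyl in place of 4-bromophenyl on an aromatic carbon. For the measured compounds named here, with no measured step to rest on, the step of a number 2.7 percentage points lower from compound 1 to compound 3 (within the scatter) is expected to be small, no larger than the scatter, in either direction. Compound 3 is therefore estimated to give about 52% in this assay, within a range from 32% to 70%.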

Compound 3, a percentage reported as inhibition, at one concentration (the size of the read-out at that concentration, not a potency): 53.2%
Compound 3: the middle estimate sits 1.2 percentage points below what was measured; the range from low to high includes it.
By their numbers in this assay, from the lowest: compounds 3, 1 and 2 (each within the scatter of the next).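

Among the compounds shown here, the step at this position reads a number 1.5 percentage points lower from compound 1 to compound 3 (within the scatter) in this assay, the first comparison in which only one place on the shared core differs. On this aromatic carbon, then, 2-methylphenyl can stand in place of 4-bromophenyl without a shift that can be told from the scatter of this assay; the two groups have the same count of heavy atoms, and neither carries a hydrogen-bond donor or acceptor. Nothing measured here offers an explanation for how closely the two compounds agree.

Only these two substituted phenyl groups can be compared at this position, and each reading comes from a single concentration, not from a potency. From the compounds shown here alone, whether a simple amine, a carboxylic acid or a phenyl bearing a longer chain would be accepted on this carbon remains open.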